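Working notes: ring swap at the chain carbon, compound 4

A few compounds are considered here, and "the series" means these few. Any claim that something is new, unique, unknown or untested is made for them only; others in the source may bear on it.

Measured so far:
compound 1 `CC(C)C(CC1C(=O)NC(=O)N1C)c1ccc(-c2ccc3cccc(F)c3c2)[nH]c1=O` — 65 nM
compound 2 `CC(C)C(c1ccc(-c2ccc3cccc(F)c3c2)[nH]c1=O)C1NC(=O)NC1=O` — 320 nM
compound 3 `CC(C)C(/C=C1\SC(=O)NC1=O)c1ccc(-c2ccc3cccc(F)c3c2)[nH]c1=O` — 27 nM

All three were run in a functional assay on CHO cells for antagonist activity at prostaglandin E2 receptor EP3 subtype (Homo sapiens), read by cAMP accumulation, with a stated time of 30 min; on this read-out higher numbers stand for weaker inhibition and lower numbers for stronger inhibition. Compound 3 stands lowest of the three numbers; its nearest neighbour is compound 1, at a 2.4-fold lower number from compound 1 to compound 3 (0.38 log units; beyond the scatter) read in reverse, and its furthest is compound 2, with a 12-fold lower number from compound 2 to compound 3 (1.07 log units; beyond the scatter).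

Compound 4 `CC(C)C(c1ccc(-c2ccc3cccc(F)c3c2)[nH]c1=O)C1C(=O)NC(=O)N1C` has not yet been measured. Against compound 3 the change is a group of 8 heavy atoms (4 carbon, 2 nitrogen, 2 oxygen; one five-membered non-aromatic ring with 2 hetero atoms) in place of a group of 8 heavy atoms (4 carbon, 1 nitrogen, 2 oxygen, 1 sulfur; one five-membered non-aromatic ring with 2 hetero atoms), on a saturated chain carbon bound to an aromatic carbon and a saturated chain carbon.

Within the data shown here, two measured steps bear on it. Among the measured compounds shown here, compound 4 carries the same ring as compound 1 but without the one-carbon link, and the closest precedent for dropping that link is a 4.9-fold higher number from compound 1 to compound 2 (0.69 log units; beyond the scatter), a modest loss. Compound 4 also shares the direct attachment with compound 2, differing only by the methyl on the ring nitrogen, and compound 2 sits furthest from compound 3 by a 12-fold lower number from compound 2 to compound 3 (1.07 log units; beyond the scatter). Taken together, compound 4 is expected to land between compound 2 and compound 1, that is, a modest to large step to a higher number in this assay than compound 3, and beyond the scatter.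

The expected step is a 5.9-fold higher number from compound 3 to compound 4 (0.77 log units; beyond the scatter). Compound 4 is estimated at 160 nM, with a range from 50 nM to 500 nM.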

Compound 4, half-maximal inhibitory concentration: 320 nM
Beside the measured number, compound 4's estimate is 2.0-fold (0.30 log units) below it, and the stated range covers the measured number.
By their numbers in this assay, from the lowest: compound 3; then compound 1; then compounds 2 and 4 (each within the scatter of the next).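

In this assay, methyl in place of hydrogen on an amide-type nitrogen in a ring shows no change at the digits printed from compound 2 to compound 4 (within the scatter), so with direct attachment to the saturated chain carbon this substitution does not separate the two rings. With the ring and its methyl held constant, 3-methyl-2,5-dioxoimidazolidin-4-yl in place of (3-methyl-2,5-dioxoimidazolidin-4-yl)methyl gives a 4.9-fold higher number from compound 1 to compound 4 (0.69 log units; beyond the scatter), which isolates the effect of removing the link on the read-out, something the earlier step to compound 2 could not do, as that step also lost the ring methyl. Replacing the whole group gives a 12-fold higher number from compound 3 to compound 4 (1.07 log units; beyond the scatter), but the ring atoms and the count of double bonds outside aromatic rings change together in this step, so it cannot be assigned to either one alone.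

Nothing at hand explains why any of these steps takes the size it does. Still open, on these data alone, is how the sulfur-containing ring reads when attached directly to the saturated chain carbon, and how a carboxylic acid, an amine or a longer chain would read at the same place.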